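The compounds below may be only part of what the source reports. "The series", "measured", "known", "first", "only" and "open" are said of these compounds alone.

Working notes on the series, read in a functional assay on MCF7 cells (Homo sapiens) for cytotoxicity, read by MTT assay, with a stated time of 72 h; a lower number here means a stronger inhibitor, a higher number a weaker inhibitor. Of the compounds shown here, two on the shared core have numbers so far. Compound 1 `Nc1ccc(Nc2c(C(=O)NCc3ccc(F)cc3)nc(Br)c3cccnc23)cc1` gives 4000 nM, and compound 2 `NCCNc1c(C(=O)NCc2ccc(F)cc2)nc(Br)c2cccnc12` gives 6000 nM. These two values lie within the scatter of each other, so the numbers do not separate compound 2 from compound 1.

Compound 3 `CNCCCNc1c(C(=O)NCc2ccc(F)cc2)nc(Br)c2cccnc12` has no number yet. Its difference from compound 2 is (methylamino)methyl in place of amino on a saturated chain carbon, two bonds along the chain from a nitrogen on an aromatic ring. The same difference, cut further out, reads 2-aminoethyl to 3-(methylamino)propyl.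

Among the measured compounds shown here, only one measured step bears on this change: a 1.5-fold higher number from compound 1 to compound 2 (0.18 log units; within the scatter), with 2-aminoethyl in place of 4-aminophenyl at the same nitrogen on an aromatic ring. For the measured compounds named here, no measured pair tests chain length or the methyl group alone, so this evidence is indirect. Since that larger replacement stayed within the scatter, no step beyond the scatter is expected in this assay, in either direction.

For compound 3 the expected value is 5000 nM, with an estimated range of 1800 nM to 14000 nM. This estimate corresponds to an expected 1.2-fold lower number from compound 2 to compound 3 (0.08 log units; within the scatter).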

Compound 3, half-maximal inhibitory concentration: > 10000 nM
Compound 3: only a limit was reported; the forecaster's own chance of this, stated with the estimate: 5%; middle value at least 2.0-fold (0.30 log units) from the limit.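

In this assay compound 3 gives > 10000 nM, which is a limit of the assay and not a number. Among the compounds shown here, at this position the change to (methylamino)methyl on the saturated chain carbon reads as an at least 1.6-fold higher number from compound 2 to compound 3 (0.22 log units; that floor lies within the scatter), so this floor alone does not separate the 3-(methylamino)propyl chain from the 2-aminoethyl chain, whereas the replacement of 4-aminophenyl on the nitrogen on the aromatic ring now reads as an at least 2.5-fold higher number from compound 1 to compound 3 (0.39 log units; beyond the scatter), the first step to pass beyond the scatter. Both steps are floors rather than measured sizes because of the limit: the limit of > 10000 nM in this assay, at which 1 of the 3 values shown sits.

From the compounds shown here alone, the true size of both steps stays open, and so does the question of whether the added chain length or the methyl group on the amine carries the change from the 2-aminoethyl chain. A 3-aminopropyl chain or a 2-(methylamino)ethyl chain on the same nitrogen would pull those two parts of the change apart on the shared core.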